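Exchanging the Group on the Ring Nitrogen of Compound 1

A few compounds are considered here, and "the series" means these few. Any claim that something is new, unique, unknown or untested is made for them only; others in the source may bear on it.

Going by the values given here, in a physicochemical assay for solubility, read by turbidimetry, measured as kinetic solubility, at pH 6.8 (on this read-out higher numbers stand for higher solubility and lower numbers for lower solubility), compound 1 (`COc1ccc(F)cc1N1C(=O)CSC1c1cccc(C(=O)NCCCCn2cccn2)c1`) gives 50000 nM, the highest of the three numbers measured so far. Compound 2 (`COc1ccc(F)cc1N1C(=O)CSC1c1cccc(C(=O)NCCCCc2ccccc2)c1`) gives 10000 nM, and compound 3 (`C#Cc1cccc(N2C(=O)CSC2c2cccc(C(=O)NCCCCc3ccccc3)c2)c1`) gives 10000 nM. Compound 4 (`O=C(NCCCCn1cccn1)c1cccc(C2SCC(=O)N2c2cc(F)ccn2)c1`) has not yet been measured. It departs from compound 1 by a single change: 4-fluoropyridin-2-yl in place of 5-fluoro-2-methoxyphenyl on an amide-type nitrogen in a ring. In short, 4-fluoropyridin-2-yl stands in place of 5-fluoro-2-methoxyphenyl on an amide-type nitrogen in a ring.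

Among the compounds with values here, the closest precedent is a change at that same place, 3-ethynylphenyl in place of 5-fluoro-2-methoxyphenyl, which gave no change at the digits printed from compound 2 to compound 3 (within the scatter). That precedent carries a different entering group and a phenyl chain end, so it is only a partial guide. The larger step, a 5.0-fold lower number from compound 1 to compound 2 (0.70 log units; beyond the scatter), arose at the chain end, a different place, and shows only that the read-out can move among these compounds. No step beyond the scatter is therefore expected, and the estimated step is no change at the digits printed from compound 1 to compound 4 (within the scatter). Compound 4 is estimated at 50000 nM, with an expected range of 20000 nM to 100000 nM.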

Compound 4, solubility: 50000 nM
Beside the measured number, compound 4's estimate shows no gap at the digits printed; low and high end bracket the measured number.
By their numbers in this assay, from the lowest: compounds 2 and 3 (each within the scatter of the next); then compounds 1 and 4 (each within the scatter of the next).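

In this assay, the step is no change at the digits printed from compound 1 to compound 4 (within the scatter) with 4-fluoropyridin-2-yl in place of 5-fluoro-2-methoxyphenyl on the amide-type nitrogen in the ring. Going by these compounds alone, the one earlier change at this place was read with a phenyl chain end, whereas this step shows a second exchange there staying within the scatter with the 1H-pyrazol-1-yl chain end, and with an aromatic ring holding a hetero atom entering for one of carbon only. No measurement at hand accounts for this absence of a step.

On these data alone, whether 4-fluoropyridin-2-yl would read the same way with the phenyl chain end of compound 2 remains open. Also open, as far as these compounds go, is how a group of another kind at this place, such as a morpholine, an aminopyridine or a benzoic acid, would read.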